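The compounds below may be only part of what the source reports. "The series", "measured", "known", "first", "only" and "open" are said of these compounds alone.

Measured in a functional assay on MCF7 cells (Homo sapiens) for antiproliferative activity; a lower number here means a stronger inhibitor, a higher number a weaker inhibitor:
- compound 1 `CC(C)=CCc1cc(C(=O)Nc2cc3ccc(OCC4CCN(C)C4)c(C)c3oc2=O)ccc1O`: 1550 nM
- compound 2 `CC(C)=CCc1cc(C(=O)Nc2cc3ccc(OCCCNC(C)C)c(C)c3oc2=O)ccc1O`: 740 nM
- compound 3 `COC(=O)CNCCCOc1ccc2cc(NC(=O)c3ccc(O)c(CC=C(C)C)c3)c(=O)oc2c1C`: 2820 nM

Compound 3 is not separated from every neighbour in this assay: the numbers show a 1.8-fold higher number from compound 1 to compound 3 (0.26 log units; within the scatter), but also a 3.8-fold higher number from compound 2 to compound 3 (0.58 log units; beyond the scatter).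

Compound 4 `CC(C)=CCc1cc(C(=O)Nc2cc3ccc(OCCCN(C)C4CCCCC4)c(C)c3oc2=O)ccc1O` carries cyclohexyl(methyl)amino in place of ((methoxycarbonyl)methyl)amino on a saturated chain carbon, three bonds along the chain from an oxygen on an aromatic ring.

The closest guide is the step that introduces (methoxycarbonyl)methyl on an amine nitrogen, a 3.8-fold higher number from compound 2 to compound 3 (0.58 log units; beyond the scatter). Read in reverse, it suggests a lower number once that group leaves. The step of a 1.8-fold higher number from compound 1 to compound 3 (0.26 log units; within the scatter) points the same way, but offers no firm support. Going by the values given here, no measured compound carries a cyclohexyl group, so the size remains uncertain, and only a modest change is expected in this assay.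

The expected step is a 2.4-fold lower number from compound 3 to compound 4 (0.37 log units; beyond the scatter).

Compound 4 is estimated at 1200 nM, with an expected range of 500 nM to 3000 nM.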

Compound 4, half-maximal inhibitory concentration: 1080 nM
Beside the measured number, compound 4's estimate is 1.1-fold (0.05 log units) above it, within the range that was stated.
By their numbers in this assay, from the lowest: compounds 2, 4, 1 and 3 (each within the scatter of the next, the first and the last beyond it).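

In this assay the position on a saturated chain carbon, three bonds along the chain from an oxygen on an aromatic ring, accepts cyclohexyl(methyl)amino, with its six-membered carbon ring and no hydrogen-bond donor, and the number falls when it replaces ((methoxycarbonyl)methyl)amino (a 2.6-fold lower number from compound 3 to compound 4 (0.42 log units; beyond the scatter)). The same group does not separate from isopropylamino (a 1.5-fold higher number from compound 2 to compound 4 (0.16 log units; within the scatter)), and 2-(cyclohexyl(methyl)amino)ethyl does not separate from 1-methylpyrrolidin-3-yl (a 1.4-fold lower number from compound 1 to compound 4 (0.16 log units; within the scatter)). Ring-bearing and open-chain amines thus sit together here, with only compound 3 beyond the scatter of compound 2 and compound 4, though not of compound 1.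

No measurement at hand explains these differences. A carboxylic acid in place of methoxycarbonyl, a morpholine ring on the chain, or a longer chain remains an open question at this position.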